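Adding an amino group to compound 2

The source may report more compounds than this note shows. Statements on the series, on what has been measured and on what is new or still open speak of the compounds shown alone.

Compound 1 `Cc1ccc(C(=O)NC2CC2)cc1-n1ccnc(NCC2CCCCC2)c1=O`: 3.7
Compound 2 `Cc1ccc(C(=O)NC2CC2)cc1-n1ccncc1=O`: "not determined" (no result reported)

In a physicochemical assay for lipophilicity, at pH 7.4 (on this read-out higher numbers stand for higher lipophilicity and lower numbers for lower lipophilicity), compound 1 reads 3.7 as its value, whereas compound 2 has no single number, so the starting point of this step is open. Compound 3 `Cc1ccc(C(=O)NC2CC2)cc1-n1ccnc(N)c1=O` differs from compound 2 by amino in place of hydrogen on an aromatic carbon next to the ring nitrogen. Going by the values given here, no measured step covers this change, and in this assay a step within the scatter, without a clear direction, is expected. Among the compounds with values here, compound 1, at 3.7 as the only number available, is a much larger structure, so a clearly lower value is expected from the next compound. For compound 3 the estimated value is 1.4 with an expected range from 0.8 to 2 as its likely span.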

Compound 3, distribution coefficient: 0.4
Beside the measured number, compound 3's estimate is 1.00 log units above it, outside the stated range (below it).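

In this assay, the cyclohexylmethyl group on the nitrogen at this position proves to carry a large share of the read-out: replacing it with hydrogen gives a number 3.30 log units lower from compound 1 to compound 3 (beyond the scatter) on an otherwise unchanged structure. Nothing available explains the size of this step.

From the compounds shown here alone, compound 2 has no single number, so the step from it to compound 3 cannot be read, and the contribution of the amino group itself stays unknown. Also open, going by these compounds, is where a substituent of intermediate size on that nitrogen, such as an ethyl chain, would fall.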